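Longer Amine Alkyls and Serotonin Receptor Binding

The source may report more compounds than this note shows. Statements on the series, on what has been measured and on what is new or still open speak of the compounds shown alone.

Compound 3 `COc1ccccc1-c1cc(CN(C)C)ccc1Cl` gives 830 nM in an assay on isolated protein for binding affinity to 5-hydroxytryptamine receptor 1B (Homo sapiens) (on this read-out higher numbers stand for weaker inhibition and lower numbers for stronger inhibition), the lowest of the two numbers available. Compound 2 `CNCc1ccc(Cl)c(-c2ccccc2OC)c1` gives 1200 nM, and the step of a 1.4-fold lower number from compound 2 to compound 3 (0.16 log units; within the scatter) does not separate the two. Compound 1 `CCCN(CCC)Cc1ccc(Cl)c(-c2ccccc2OC)c1` reports only > 10000 nM, which is a limit of the assay rather than a number. Compound 4 `CCN(CC)Cc1ccc(Cl)c(-c2ccccc2OC)c1` differs from compound 3 in one place: diethylamino in place of dimethylamino on a saturated chain carbon bound to an aromatic carbon. The steps of an at least 12-fold lower number from compound 1 to compound 3 (1.08 log units; beyond the scatter) and an at least 8.3-fold lower number from compound 1 to compound 2 (0.92 log units; beyond the scatter) both show that two propyl chains on this nitrogen carry a far higher number than one or two methyls. Diethylamino lies between those sizes, so a rise in the number is expected, estimated as a 3.6-fold higher number from compound 3 to compound 4 (0.56 log units; beyond the scatter). Compound 4 is therefore expected to give 3000 nM, with a range from 1000 nM to 10000 nM.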

Compound 4, inhibition constant: > 10000 nM
Compound 4: only a limit was reported; the forecaster's own chance of this, stated with the estimate: 20%; middle value at least 3.3-fold (0.52 log units) from the limit.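

In this assay, two ethyl groups on the amine nitrogen are already enough to reach the limit, with an at least 12-fold higher number from compound 3 to compound 4 (1.08 log units; beyond the scatter) and an at least 8.3-fold higher number from compound 2 to compound 4 (0.92 log units; beyond the scatter). The sharp rise therefore does not need chains as long as propyl, and among these compounds only methylamino and dimethylamino give readable numbers. The step between compound 1 and compound 4 cannot be read, as both values are limits: the limit of > 10000 nM in this assay, at which 2 of the 4 values shown sit.

Still open, as far as these compounds go, is how an amine carrying one methyl and one ethyl, or a single ethyl, would read. So is whether a ring amine such as pyrrolidine would behave like diethylamino.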